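Working notes: aryl exchange on the aromatic nitrogen

This account rests on a few compounds, and the source may have more. Where it says the series, first, only, none or still open, it means among the compounds named here.

The series is read in an ADME assay on HEK293 cells (Homo sapiens) for inhibition, read by MTT assay, with a stated time of 48 h, tested at 25 uM; on this read-out lower numbers stand for less inhibition and higher numbers for more inhibition at the one concentration tested (going by the name of the read-out). Compound 1 `Cc1ccc(-n2cc(COc3ccc4c(c3)CCC4)nn2)cc1` has no number there; in this assay compound 1 gives "not determined" (no result reported). Compound 2 `Brc1ccccc1-n1cc(COc2ccc3c(c2)CCC3)nn1` is thus the only compound with a value: in this assay compound 2 gives 16.5%, a low read-out at the single concentration, and it stands alone on the numbers shown. Compound 3 `COc1ccc(-n2cc(COc3ccc4c(c3)CCC4)nn2)cc1` is not yet measured. Relative to compound 2 it differs as follows: 4-methoxyphenyl in place of 2-bromophenyl on an aromatic nitrogen. Among the measured compounds shown here, no step between two measured compounds exists in this set, so there is no measured change to lean on. For the measured compounds named here, with only one value in hand, the step of a number 2.5 percentage points lower from compound 2 to compound 3 (within the scatter) is expected to be small, most likely within the scatter and without a clear direction. For compound 3 in this assay the estimated inhibition is 14%, with a range from 3% to 30%.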

Compound 3, a percentage reported as inhibition, at one concentration (the size of the read-out at that concentration, not a potency): 21.1%
The estimate for compound 3 lay 7.1 percentage points below the measured number; measured number inside the range.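

In this assay, among the compounds shown here, replacing 2-bromophenyl with 4-methoxyphenyl on the aromatic nitrogen gives a number 4.6 percentage points higher from compound 2 to compound 3 (within the scatter), the first measured step at this position, and it shows no clear effect of this exchange on the read-out. The two aryl groups differ in both the substituent and where it sits on the phenyl ring, so this single step cannot separate those two changes, and the small size of the step holds only for this pair. No measurement at hand bears on the reason for this result.

Compound 1 gives "not determined" (no result reported), so steps involving compound 1 cannot be read. From the compounds shown here alone, whether an amine or a carboxylic acid on the phenyl ring, or a longer chain in place of the aryl group, would move the read-out beyond the scatter remains open.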